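Series notes: carbonyl substituent change and tolerated concentration

A few compounds are considered here, and "the series" means these few. Any claim that something is new, unique, unknown or untested is made for them only; others in the source may bear on it.

Compound 1 `N#Cc1ccc(C(=O)NC(=S)N2CCc3c(OCCCCCOc4ccc(Cl)cc4)cccc32)cc1` gives in an ADME assay on Huh-7 cells (Homo sapiens) for cytotoxicity (a lower number here means that less compound is tolerated, a higher number that more compound is tolerated), a limit of the assay, > 50000 nM.
Compound 2 `O=C(NC(=S)N1CCc2c(OCCCCCOc3ccc(Cl)cc3)cccc21)c1ccc(C(F)(F)F)cc1` gives in this assay 32700 nM.
Compound 3 `CN(C)c1ccc(C(=O)NC(=S)N2CCc3c(OCCCCCOc4ccc(Cl)cc4)cccc32)cc1` gives in this assay a limit of the assay, > 50000 nM.

Compound 3 stands at the upper limit of the assay, the value being a limit and not a number; this is the limit of > 50000 nM in this assay, at which 2 of the 3 values shown sit. Among the measured steps, the change from compound 1 to compound 2 reads an at least 1.5-fold lower number from compound 1 to compound 2 (0.18 log units; that floor lies within the scatter), the change from compound 2 to compound 3 reads an at least 1.5-fold higher number from compound 2 to compound 3 (0.18 log units; that floor lies within the scatter), and the change from compound 1 to compound 3 reads a step that the two limits leave unreadable from compound 1 to compound 3. All three concern only the substituent on the aromatic ring attached to the carbonyl carbon, and none of them clears the scatter.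

Compound 4 `O=C(CCc1ccccc1)NC(=S)N1CCc2c(OCCCCCOc3ccc(Cl)cc3)cccc21` is not yet measured. Its difference from compound 3 is phenethyl in place of 4-(dimethylamino)phenyl on a carbonyl carbon. Among the measured compounds shown here, no measured step covers a replacement of the whole aryl group at the carbonyl carbon, so no step bears on it directly; what the measured steps show is that the three variations at this position stay within a narrow band near the limit.

Compound 4 is therefore expected to remain close to that band, with an estimate of 40000 nM and a range of 15000 nM to 100000 nM. The step this estimate means from compound 3 to compound 4 is expected to be an at least 1.2-fold lower number from compound 3 to compound 4 (0.09 log units; that floor lies within the scatter), not beyond the scatter.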

Compound 4, half-maximal cytotoxic concentration: > 50000 nM
Compound 4: only a limit was reported; the forecaster's own chance of this, stated with the estimate: 50%; middle value at least 1.2-fold (0.09 log units) from the limit.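

In this assay compound 4 gives > 50000 nM, which is a limit of the assay and not a number. Among the compounds shown here, the earlier compounds varied only the substituent on the aromatic ring, whereas this change replaces the whole 4-(dimethylamino)phenyl group with phenethyl on the carbonyl carbon, and the result still shows no readable drop: the one readable step is an at least 1.5-fold higher number from compound 2 to compound 4 (0.18 log units; that floor lies within the scatter), and the steps to compound 4 from compound 1 and from compound 3 cannot be read, as both ends of each are limits. An aryl group bonded directly to the carbonyl carbon is thus not required for a compound to reach the upper limit, with compound 2 remaining the only compound that gives a number, and the series now sits mostly at that ceiling: the limit of > 50000 nM in this assay, at which 3 of the 4 values shown sit.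

From the compounds shown here alone, how far compound 1, compound 3 and compound 4 lie beyond the limit stays unknown, so no order among them can be given. Also open, going by these compounds, is whether a carboxylic acid or a longer alkyl chain on the carbonyl carbon would stay at this limit or give a number that can be compared.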